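The source may report more compounds than this note shows. Statements on the series, on what has been measured and on what is new or still open speak of the compounds shown alone.

The measured compounds:

Compound 1, `O=C(Nc1ccccn1)c1ccccc1-c1ccccc1`: in an in vitro functional assay on HEK ts201 cells for antagonist activity at Neuronal acetylcholine receptor; alpha4/beta2 (Homo sapiens), read by fluorescence and calcium flux (on this read-out lower numbers stand for stronger inhibition and higher numbers for weaker inhibition), compound 1 gives 13600 nM.
Compound 2, `O=C(NCC1CCCN(CCCc2ccccc2)C1)c1ccccc1-c1ccccc1`: in this assay compound 2 gives 20000 nM.
Compound 3, `O=C(Nc1cccc2ccccc12)c1ccccc1-c1ccccc1`: in this assay compound 3 gives 10700 nM.

Compound 1 holds the second highest of the three numbers. Its nearest neighbour is compound 3 and its furthest is compound 2, but both gaps fall inside the usual scatter of repeated measurements, so the three compounds cannot be set in any order on these data; all three are weak in this assay.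

Compound 4, `O=C(NCc1ccccc1)c1ccccc1-c1ccccc1`, has not yet been measured. It differs from compound 1 in one place: benzyl in place of pyridin-2-yl on an amide-type nitrogen. Among the compounds with values here, no step between two measured compounds involves this change, so nothing here shows how it will read. With every measured number sitting close to the others, the step is expected to stay within the scatter, in no clear direction, and the expected step is a 1.1-fold higher number from compound 1 to compound 4 (0.04 log units; within the scatter). Compound 4 is estimated at 15000 nM, with a range from 5000 nM to 45000 nM.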

Compound 4, half-maximal inhibitory concentration: 7500 nM
Estimate against measurement, compound 4: 2.0-fold (0.30 log units) above, within the range that was stated.
By their numbers in this assay, from the lowest: compounds 4, 3, 1 and 2 (each within the scatter of the next, the first and the last beyond it).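

Within the data shown here, on the amide-type nitrogen of the shared core, benzyl in place of pyridin-2-yl gives the first direct comparison at this position, and the step (a 1.8-fold lower number from compound 1 to compound 4 (0.26 log units; within the scatter)) lies within the scatter, so the two groups cannot be told apart in this assay. The change also takes away the hydrogen-bond acceptor counted for pyridin-2-yl, since benzyl has none, and this single step shows no clear loss or gain of inhibition with that exchange. No measurement offered here gives a reason for this result.

The compounds shown leave open how a longer chain such as phenethyl would read on this nitrogen. They also do not tell whether an amine or a carboxylic acid carried on the benzyl group would move the number beyond the scatter.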